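Removing One Trifluoromethyl Group From Compound 2

A few compounds are considered here, and "the series" means these few. Any claim that something is new, unique, unknown or untested is made for them only; others in the source may bear on it.

Compound 2 `COc1cc(Cl)cc(-c2nn(-c3cccc(NC(=O)Nc4cc(C(F)(F)F)cc(C(F)(F)F)c4)c3)cc2-c2ccncc2)c1` was examined in a functional assay on NCI-H23 cells (Homo sapiens) for inhibition, read by sulforhodamine B assay, with a stated time of 48 h, tested at 100 uM (a higher number here means a weaker effect of the compound at the concentration tested, a lower number a stronger effect), where compound 2 gives -58%. This is the lowest of the two numbers available. The nearest is compound 1 `O=C(Nc1cccc(-n2cc(-c3ccncc3)c(-c3cc(O)cc(Cl)c3)n2)c1)Nc1ccc(Cl)c(Cl)c1`, which in this assay gives -35%, a number that stands higher than that of compound 2 by more than the usual scatter.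

Compound 3 `COc1cc(Cl)cc(-c2nn(-c3cccc(NC(=O)Nc4cccc(C(F)(F)F)c4)c3)cc2-c2ccncc2)c1` has not yet been measured. Its difference from compound 2 is hydrogen in place of trifluoromethyl on an aromatic carbon. Going by the values given here, no pair of measured compounds that differ in only one place is available, so the effect of this change can only be guessed.

Compound 3 is expected to give -45%, with a range from -75% to -10%. The estimated step of a number 13 percentage points higher from compound 2 to compound 3 (beyond the scatter) is expected to be small, towards a somewhat higher number, and may well lie within the scatter.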

Compound 3, a percentage reported as activity, at one concentration (the size of the read-out at that concentration, not a potency): -40%
Compound 3: the middle estimate sits 5 percentage points below what was measured, and the stated range covers the measured number.
By their numbers in this assay, from the lowest: compound 2; then compounds 3 and 1 (each within the scatter of the next).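

This is the first pair shown that differs in only one place, so in this assay the swap of trifluoromethyl for hydrogen can be read directly as a number 18 percentage points higher from compound 2 to compound 3 (beyond the scatter) and no longer has to be guessed. The step is modest but beyond the usual scatter, so the second trifluoromethyl group on this aromatic ring does matter for the read-out, although compound 3, with one such group left, still gives -40% in the same test. Nothing available explains why this change moves the number.

The compounds shown leave open whether a chlorine atom, a methyl group or an amine on this aromatic carbon would give a number closer to that of compound 2 or of compound 3. Also open, on these data alone, is whether the step would keep its size with the remaining trifluoromethyl group replaced.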